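The source may hold more compounds than are shown below. What is called first, only, known or untested is meant among the compounds shown, and "the series" means these compounds.

Measured so far:
compound 1, `C#CCSc1nc(Nc2ccccc2Cl)c(C#N)c(-c2ccccc2)n1` — in a functional assay on ECa-109 cells (Homo sapiens) for inhibition, read by MTT assay, with a stated time of 72 h (a higher number here means a weaker inhibitor, a lower number a stronger inhibitor), compound 1 gives > 128000 nM, a limit of the assay and not a number
compound 2, `N#Cc1c(Nc2ccccc2Cl)nc(SCc2cn(Cc3ccccc3Cl)nn2)nc1-c1ccccc1` — in this assay compound 2 gives 28500 nM

Among the measured compounds shown here, compound 2 therefore holds the only number in this assay. The value of compound 1 is a limit of the assay and not a number (the limit of > 128000 nM in this assay, at which 1 of the 2 values shown sits). Compound 3, `N#Cc1c(Nc2cccc([N+](=O)[O-])c2)nc(SCc2cn(Cc3ccccc3Cl)nn2)nc1-c1ccccc1`, has not yet been measured. It differs from compound 2 in one place: 3-nitrophenyl in place of 2-chlorophenyl on a nitrogen on an aromatic ring. For the measured compounds named here, no step between two measured compounds shows what such an exchange does here, so the account can only expect a step from compound 2 to compound 3 of a 1.2-fold higher number from compound 2 to compound 3 (0.09 log units; within the scatter), a change expected to stay within the usual scatter. Compound 3 is accordingly estimated at 35000 nM, with a range from 9000 nM to 120000 nM, and with some chance that the assay reports only a limit and no number.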

Compound 3, half-maximal inhibitory concentration: > 64000 nM
Compound 3 gave a limit, no number (the forecaster's own chance of this, stated with the estimate: 25%); at least 1.8-fold (0.26 log units) between middle value and limit.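

Among the compounds shown here, at this position, on a nitrogen on an aromatic ring, the exchange of 2-chlorophenyl for 3-nitrophenyl gives in this assay an at least 2.2-fold higher number from compound 2 to compound 3 (0.35 log units; beyond the scatter), the first step that can be read at this place. It shows that the aryl group on this nitrogen is not interchangeable, as the step runs towards weaker inhibition and lies beyond the scatter. As far as these compounds go, its full size remains unknown, because compound 3 gave only a limit of the assay and not a number: the limit of > 64000 nM in this assay, at which 1 of the 3 values shown sits.

The compounds shown do not separate the loss of 2-chlorophenyl from the arrival of 3-nitrophenyl. They also leave open how a plain phenyl, or a phenyl carrying an amine or a carboxylic acid, would behave on this nitrogen.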